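Chain extension of an alkynyl ester of a diacetylated cinnamic acid

The source may hold more compounds than are shown below. What is called first, only, known or untested is meant among the compounds shown, and "the series" means these compounds.

Measured so far:
compound 1, `CC(=O)Oc1ccc(/C=C/C(=O)O)cc1OC(C)=O`: > 10000 nM
compound 2, `C#CCCCCOC(=O)/C=C/c1ccc(OC(C)=O)c(OC(C)=O)c1`: 920 nM

Compound 1 carries a free acid. In an assay for inhibition of Polyunsaturated fatty acid 5-lipoxygenase (Homo sapiens), read by HPLC, with a stated time of 10 min (on this read-out lower numbers stand for stronger inhibition and higher numbers for weaker inhibition), compound 1 reaches only the limit > 10000 nM, so no number is known for it. Compound 2 carries a hex-5-yn-1-yl group on an oxygen next to the carbonyl group; in this assay compound 2 gives 920 nM. Among the compounds with values here, the step of an at least 10-fold lower number from compound 1 to compound 2 (1.03 log units; beyond the scatter) is the only measured step; one of the two values sits at the limit of > 10000 nM in this assay, at which 1 of the 2 values shown sits, so compound 2 is the one compound with a number and stands on its own.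

Compound 3, `C#CCCCCCCCCOC(=O)/C=C/c1ccc(OC(C)=O)c(OC(C)=O)c1`, differs from compound 2 in one place: hex-5-yn-1-yl in place of ethynyl on a saturated chain carbon, four bonds along the chain from an oxygen next to a carbonyl group. Within the data shown here, no measured step touches a chain of this kind, since the step from compound 1 to compound 2 concerns the presence of the chain, not its length. With nothing to set a direction, compound 3 is expected to stay close to compound 2, with a step of a 1.2-fold lower number from compound 2 to compound 3 (0.06 log units; within the scatter) not beyond the scatter. The estimate for compound 3 in this assay is 800 nM, between 250 nM and 3000 nM.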

Compound 3, half-maximal inhibitory concentration: 180 nM
Beside the measured number, compound 3's estimate is 4.4-fold (0.65 log units) above it; measured number outside the range, below it.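

In this assay, within the data shown here, a 5.1-fold lower number from compound 2 to compound 3 (0.71 log units; beyond the scatter) shows that this position responds to the length of the chain, whereas the earlier step from the free acid showed only that placing a hex-5-yn-1-yl group on the oxygen next to the carbonyl group mattered. The group that enters and the group that leaves each carry one triple bond outside aromatic rings and count no hydrogen-bond donors or acceptors, so the change at this saturated chain carbon lies in added carbon alone, and the triple bond is kept in both compounds. Nothing measured here gives a reason for this step.

With only two chain lengths carrying a number, the compounds shown cannot tell whether a still longer chain would lower the number further or reverse the step, so no trend with length can be claimed. They also leave open whether the triple bond itself contributes, which a saturated alkyl chain of the same length would address, and how a chain bearing an amine or a carboxylic acid would behave at this position.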